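Triazole substituent survey on a bis(benzyloxy)furanone core

This account rests on a few compounds, and the source may have more. Where it says the series, first, only, none or still open, it means among the compounds named here.

Measured so far in a functional assay on HepG2 cells (Homo sapiens) for antiproliferative activity, read by MTT assay, with a stated time of 72 h; on this read-out lower numbers stand for stronger inhibition and higher numbers for weaker inhibition:
Compound 1 `Cc1ccc(S(=O)(=O)NCc2cn(C[C@H](O)[C@H]3OC(=O)C(OCc4ccccc4)=C3OCc3ccccc3)nn2)cc1`, 24900 nM
Compound 2 `COc1ccc(-c2cn(C[C@H](O)[C@H]3OC(=O)C(OCc4ccccc4)=C3OCc3ccccc3)nn2)cc1`, 46400 nM
Compound 3 `O=C1O[C@H]([C@@H](O)Cn2cc(CCO)nn2)C(OCc2ccccc2)=C1OCc1ccccc1`, 68100 nM

Compound 3 gives the highest number of the three. Against compound 2 the gap is a 1.5-fold higher number from compound 2 to compound 3 (0.17 log units; within the scatter), so the two cannot be told apart; against compound 1 it is a 2.7-fold higher number from compound 1 to compound 3 (0.44 log units; beyond the scatter), a modest step beyond the scatter. The whole spread of the set is therefore narrow.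

Compound 4 `O=C1O[C@H]([C@@H](O)Cn2cc(C3CC3)nn2)C(OCc2ccccc2)=C1OCc1ccccc1` is not yet measured. Its change from compound 3 is cyclopropyl in place of 2-hydroxyethyl on an aromatic carbon. Among the measured compounds shown here, the steps that bear on it are those that swap the group on the same aromatic carbon: a 1.5-fold higher number from compound 2 to compound 3 (0.17 log units; within the scatter) and a 1.9-fold higher number from compound 1 to compound 2 (0.27 log units; within the scatter), both within the scatter, and a 2.7-fold higher number from compound 1 to compound 3 (0.44 log units; beyond the scatter), modest. None of the groups swapped so far resembles cyclopropyl closely, so the direction is uncertain; the small size of all three steps argues for little movement.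

Compound 4 is expected to give 50000 nM in this assay, within 20000 nM to 120000 nM, which means an expected step of a 1.4-fold lower number from compound 3 to compound 4 (0.13 log units; within the scatter), leaning toward a lower number but not beyond the scatter.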

Compound 4, half-maximal inhibitory concentration: 38100 nM
Compound 4: middle estimate off by 1.3-fold (0.12 log units), on the high side; the range from low to high includes it.
By their numbers in this assay, from the lowest: compounds 1, 4, 2 and 3 (each within the scatter of the next, the first and the last beyond it).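

In this assay, cyclopropyl, with 0 hydrogen-bond donors and 0 hydrogen-bond acceptors, replaces 2-hydroxyethyl on this aromatic carbon of the triazole within the scatter (a 1.8-fold lower number from compound 3 to compound 4 (0.25 log units; within the scatter)), so these compounds give no sign that the hydroxyl of that chain is needed for the antiproliferative read-out. The small ring also cannot be told apart from either larger group at the same carbon: 4-methoxyphenyl (a 1.2-fold lower number from compound 2 to compound 4 (0.09 log units; within the scatter)) or (((4-methylphenyl)sulfonyl)amino)methyl (a 1.5-fold higher number from compound 1 to compound 4 (0.18 log units; within the scatter)), which leaves compound 4 within the scatter of all three earlier compounds and adds no further separation to the one gap beyond it, between compound 1 and compound 3. Nothing available accounts for how flat this position is.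

On these data alone, it remains open whether an amine, a carboxylic acid or a longer alkyl chain on this carbon would move the number beyond the scatter in either direction. As far as these compounds go, it is also open whether replacing a benzyloxy group on the shared core, or the hydroxyl on the linking chain, would have a larger effect than any substituent change on the triazole seen here.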